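A few compounds are considered here, and "the series" means these few. Any claim that something is new, unique, unknown or untested is made for them only; others in the source may bear on it.

Working notes on the series. In a functional assay on A375-C5 cells (Homo sapiens) for inhibition, read by sulforhodamine B assay, with a stated time of 48 h (a lower number here means a stronger inhibitor of growth, a higher number a weaker inhibitor of growth), compound 1 `COC(=O)c1sc2cc(C#Cc3ccccn3)cnc2c1N` gives 13900 nM. Compound 2 `COC(=O)c1sc2cc(C#Cc3ccc(OC)cc3)cnc2c1N` sits at the limit of > 37500 nM in this assay, at which 1 of the 2 values shown sits, so its value > 37500 nM is a limit of the assay and not a number. Among the compounds with values here, the single measured step, an at least 2.6-fold higher number from compound 1 to compound 2 (0.43 log units; beyond the scatter), runs in the weakening direction. Compound 3 `COC(=O)c1sc2cc(C#Cc3cccc(N)c3)cnc2c1N` differs from compound 2 by 3-aminophenyl in place of 4-methoxyphenyl on a triple-bonded carbon. Within the data shown here, no measured step tests this particular change, and the step from compound 1 to compound 2 concerns a different replacement. Compound 3 is expected to stay near the weak end, with an at least 1.2-fold lower number from compound 2 to compound 3 (0.09 log units; that floor lies within the scatter) estimated as no step beyond the scatter, giving an estimate of 30000 nM within 8000 nM to 120000 nM.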

Compound 3, concentration for 50% growth inhibition: 11600 nM
For compound 3 the middle estimate is 2.6-fold (0.41 log units) above the measured one; the measured number falls inside the stated range.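

In this assay, 3-aminophenyl on the triple-bonded carbon gives an at least 3.2-fold lower number from compound 2 to compound 3 (0.50 log units; beyond the scatter). Compound 2 holds only a limit, not a number: the limit of > 37500 nM in this assay, at which 1 of the 3 values shown sits. Replacing pyridin-2-yl with 3-aminophenyl gives a 1.2-fold lower number from compound 1 to compound 3 (0.08 log units; within the scatter), so a six-membered aromatic ring of carbon only at this place does not by itself weaken growth inhibition, and the weakening seen so far is confined to 4-methoxyphenyl.

From the compounds shown here alone, it remains open whether the amine itself or its place on the ring accounts for the difference from compound 2. A 4-aminophenyl or 3-methoxyphenyl group on this carbon would separate the two.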